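The source may report more compounds than this note shows. Statements on the series, on what has been measured and on what is new or still open speak of the compounds shown alone.

Compound 1 `CCCCN(c1nc2c(CO)cccc2o1)[C@H](C)c1ccc(-c2ccccc2-c2nnn[nH]2)cc1` was measured in an ADME assay on the whole organism (plasma, Macaca fascicularis) for protein binding, read by LC-MS, using equilibrium dialysis and cassette dosing, with a stated time of 24 h, at a dose of 1 mg/kg by the oral route (a higher number here means a larger unbound share of the compound, a lower number a smaller unbound share), and gives 0.00112. Compound 2 `Cc1ccc(-c2nc(=O)o[nH]2)c(-c2ccc([C@@H](C)N(CC3CC3)c3nc4c(C(=O)O)cccc4o3)cc2)c1` gives 0.00023 in this assay, so compound 1 stands highest of the two numbers, with compound 2 the nearest and beyond the scatter below it. Compound 3 `CCCCN(c1nc2c(NC(C)=O)cccc2o1)[C@H](C)c1ccc(-c2ccccc2-c2nnn[nH]2)cc1` is not yet measured in this assay. It differs from compound 1 in one place: acetamido in place of hydroxymethyl on an aromatic carbon. For the measured compounds named here, no measured pair shows this change, so a step of this kind is expected to stay within the scatter, in no clear direction, and the expected step is a 1.1-fold lower number from compound 1 to compound 3 (0.05 log units; within the scatter). Compound 3 is therefore expected to give 0.001, with a range from 0.0004 to 0.0025.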

Compound 3, unbound fraction: 0.00102
The estimate for compound 3 lay 1.0-fold (0.01 log units) below the measured number; the measured number falls inside the stated range.
By their numbers in this assay, from the lowest: compound 2; then compounds 3 and 1 (each within the scatter of the next).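

In this assay, for the compounds shown here, acetamido in place of hydroxymethyl on this aromatic carbon gives a 1.1-fold lower number from compound 1 to compound 3 (0.04 log units; within the scatter), the first direct reading of a single change at this position. This swap keeps the printed hydrogen-bond donor and acceptor counts the same, and the two compounds cannot be told apart by their unbound fractions. Nothing measured here explains this result. On these data alone, whether an amine or a methoxy group on this carbon would move the number beyond the scatter remains open. So does whether this swap would behave alike with a different chain on the ring nitrogen's neighbour elsewhere in the core.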